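The compounds below may be only part of what the source reports. "The series", "measured", "known", "first", "only" and "open" are said of these compounds alone.

In a functional assay on CCRF-CEM cells (Homo sapiens) for antiproliferative activity (a lower number here means a stronger inhibitor, a higher number a weaker inhibitor), compound 1 `COc1cc(C(=O)c2sc(-c3ccc(-c4ccccc4)cc3)cc2N)cc(OC)c1OC` reads > 10000 nM, and this is a limit of the assay, not a number. Within the data shown here, compound 2 `COc1cc(C(=O)c2sc(-c3ccc(Cl)cc3)cc2N)cc(OC)c1OC` gives 70 nM, the only actual number so far. Among the measured compounds shown here, the one measured step, chloro in place of phenyl on an aromatic carbon, is large: an at least 140-fold lower number from compound 1 to compound 2 (2.15 log units; beyond the scatter).

Compound 3 `COc1cc(C(=O)c2sc(-c3ccc(I)cc3)cc2N)cc(OC)c1OC` differs from compound 2 by a single change, iodo in place of chloro on an aromatic carbon, para to a large group. Only the measured step bears on this change, and it bears loosely. That step, an at least 140-fold lower number from compound 1 to compound 2 (2.15 log units; beyond the scatter), removed a phenyl, whereas here no ring enters or leaves, so only a small part of its size is expected to carry over. Its direction gives a weak hint, since compound 1, with phenyl at this place, has the higher reading in this assay. The expected move is a modest one towards a higher number, a 1.7-fold higher number from compound 2 to compound 3 (0.23 log units; within the scatter). For compound 3 the estimated value is 120 nM, with an expected range from 30 nM to 900 nM.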

Compound 3, half-maximal inhibitory concentration: 150 nM
Beside the measured number, compound 3's estimate is 1.3-fold (0.10 log units) below it, within the range that was stated.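

In this assay, among these compounds, the change from 4-chlorophenyl to 4-iodophenyl is the first comparison at this place that exchanges one single atom for another, and it gives a modest step: a 2.1-fold higher number from compound 2 to compound 3 (0.33 log units; beyond the scatter). The exchange of phenyl for iodo at the same place gives a far larger one, an at least 66-fold lower number from compound 1 to compound 3 (1.82 log units; beyond the scatter), so the heavy loss seen with phenyl is not shared by every replacement of chloro, and a second halogen keeps the reading in the same broad range as compound 2. Compound 1 stands at a limit of the assay and not at a number, so the true size of both steps from it stays unknown: the limit of > 10000 nM in this assay, at which 1 of the 3 values shown sits.

With only chloro, iodo and phenyl at this place, the compounds shown give two halogens and one ring, which is too little to support any trend across substituents. On these data alone, how a fluoro, a methoxy, an amine or a short alkyl chain would read here remains open, as does whether any group at this place could give a lower number than compound 2.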